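The source may report more compounds than this note shows. Statements on the series, on what has been measured and on what is new or still open speak of the compounds shown alone.

Measured so far:
compound 1 `CN1CCN(CCCN(c2nc3cc(F)c(F)cc3[nH]2)[C@@H]2CC[C@]3(c4cccc(CO)c4)C[C@@H]3C2)CC1`: 70.8 nM
compound 2 `CN1CCN(CCCN(c2nc3cc(F)c(F)cc3[nH]2)[C@@H]2CC[C@]3(c4cccc(CN5CC[C@H](O)C5)c4)C[C@@H]3C2)CC1`: 441 nM

Among the measured compounds shown here, in an assay on isolated protein for binding affinity to melanin-concentrating hormone receptor 1 (Homo sapiens) (on this read-out higher numbers stand for weaker inhibition and lower numbers for stronger inhibition), compound 1 gives 70.8 nM and compound 2 gives 441 nM; compound 2 therefore carries the higher of the two numbers, its only neighbour being compound 1 with a 6.2-fold higher number from compound 1 to compound 2 (0.79 log units; beyond the scatter). Compound 3 `CN1CCN(CCCN(c2nc3cc(F)c(F)cc3[nH]2)[C@@H]2CC[C@]3(c4cccc(CN5CCC[C@H]5CO)c4)C[C@@H]3C2)CC1` is not yet measured. It differs from compound 2 as follows: 2-(hydroxymethyl)pyrrolidin-1-yl in place of 3-hydroxypyrrolidin-1-yl on a saturated chain carbon bound to an aromatic carbon. For the measured compounds named here, the one measured step, a 6.2-fold higher number from compound 1 to compound 2 (0.79 log units; beyond the scatter), concerns the exchange of a hydroxy for the whole 3-hydroxypyrrolidin-1-yl group and so bears on compound 3 only indirectly; compound 3 keeps a pyrrolidine bearing one hydroxyl, with the hydroxyl moved from the ring onto a methyl. Going by the values given here, no measured step tests that move. The expectation for compound 3 in this assay is therefore a step from compound 2 of a 1.1-fold lower number from compound 2 to compound 3 (0.04 log units; within the scatter), that is, no change beyond the scatter. The estimate for compound 3 is 400 nM, with a range from 150 nM to 1200 nM.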

Compound 3, inhibition constant: 3000 nM
Compound 3: the middle estimate sits 7.5-fold (0.88 log units) below what was measured, outside the stated range (above it).
By their numbers in this assay, from the lowest: compound 1; then compound 2; then compound 3.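

In this assay, the two pyrrolidines on the saturated chain carbon bound to an aromatic carbon are not interchangeable: with the ring, the hydrogen-bond donor and acceptor counts unchanged, 2-(hydroxymethyl)pyrrolidin-1-yl in place of 3-hydroxypyrrolidin-1-yl gives a 6.8-fold higher number from compound 2 to compound 3 (0.83 log units; beyond the scatter). Measured against the simple hydroxy, the same group gives a 42-fold higher number from compound 1 to compound 3 (1.63 log units; beyond the scatter), so at this position the outcome depends on how the pyrrolidine is substituted and not merely on a pyrrolidine being present. Nothing available accounts for this difference between the two pyrrolidines.

The compounds shown leave open whether the step follows the hydroxymethyl group itself, its place on the ring or its stereocentre. A plain pyrrolidin-1-yl, 3-(hydroxymethyl)pyrrolidin-1-yl and the opposite stereoisomer of 2-(hydroxymethyl)pyrrolidin-1-yl would separate these readings.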